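The source may report more compounds than this note shows. Statements on the series, on what has been measured and on what is new or still open speak of the compounds shown alone.

Values in a functional assay on NCI-H661 cells (Homo sapiens) for cytotoxicity, read by WST assay, with a stated time of 72 h; a higher number here means a weaker inhibitor, a lower number a stronger inhibitor:
- compound 1 `COc1cc2c(Nc3nc4ccc(C(=O)Nc5c(C)cc(C)cc5C)cc4s3)ncnc2cc1OCCCN1CCC(C)CC1`: 7700 nM
- compound 2 `COc1cc2c(Nc3nc4ccc(C(=O)Nc5c(C)cccc5C)cc4s3)ncnc2cc1OCCCN1CCCC1`: > 100000 nM (a limit)
- compound 3 `COc1cc2c(Nc3nc4ccc(C(=O)Nc5c(C)cccc5C)cc4s3)ncnc2cc1OCCCN1CCCCC1`: > 100000 nM (a limit)

In this assay, among the compounds with values here, compound 1 gives the only true number, 7700 nM. Beyond compound 1 the series offers only (the limit of > 100000 nM in this assay, at which 2 of the 3 values shown sit).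

Compound 4 `COc1cc2c(Nc3nc4ccc(C(=O)Nc5c(C)cccc5Cl)cc4s3)ncnc2cc1OCCCN1CCC(C)CC1` is unmeasured. The change is 2-chloro-6-methylphenyl in place of 2,4,6-trimethylphenyl on an amide-type nitrogen.

Within the data shown here, the one measured step, a step that the two limits leave unreadable from compound 2 to compound 3, concerns a different change and gives no size to carry over. The expectation therefore stays anchored on compound 1 at 7700 nM, with no shift beyond the scatter and a wide margin.

The expected change is a 1.1-fold lower number from compound 1 to compound 4 (0.04 log units; within the scatter).

The estimate for compound 4 is 7000 nM, with an expected range of 2000 nM to 30000 nM.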

Compound 4, half-maximal inhibitory concentration: 7900 nM
Compound 4: middle estimate off by 1.1-fold (0.05 log units), on the low side; low and high end bracket the measured number.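

In this assay, 2-chloro-6-methylphenyl in place of 2,4,6-trimethylphenyl on the amide-type nitrogen gives a 1.0-fold higher number from compound 1 to compound 4 (0.01 log units; within the scatter). Within the data shown here, this is the first readable step at this position: the entering group has one fewer heavy atom and carries a chlorine, yet the two compounds read alike. Nothing at hand gives a cause for this.

Still open, going by these compounds, is whether an unsubstituted phenyl or a pyridinyl group on that nitrogen would read the same. Also open, on these data alone, is whether this swap would read the same with a morpholine at the chain end.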